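From thiophen-2-yl to (naphthalen-1-yl)methyl

The source may hold more compounds than are shown below. What is called first, only, known or untested is meant among the compounds shown, and "the series" means these compounds.

In an ADME assay on HEK-293T cells (Homo sapiens) for inhibition, read by CCK-8 assay, with a stated time of 48 h, tested at 20 uM (a higher number here means more inhibition of growth at the concentration tested, a lower number less inhibition of growth), compound 1 `COc1ccc(S(=O)(=O)Oc2ccccc2/C=C(\C#N)C(=O)Nc2nnc(-c3cccs3)s2)cc1` gives 40%. Compound 2 `N#C/C(=C\c1ccccc1OS(=O)(=O)c1ccc([N+](=O)[O-])cc1)C(=O)Nc1nnc(-c2cccs2)s1` gives 33%, within the scatter of compound 1. Compound 3 `Cc1nnc(NC(=O)/C(C#N)=C/c2cccc(OS(C)(=O)=O)c2)s1` gives 20%, lower than both and beyond the scatter.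

Compound 4 `COc1ccc(S(=O)(=O)Oc2ccccc2/C=C(\C#N)C(=O)Nc2nnc(Cc3cccc4ccccc34)s2)cc1` carries (naphthalen-1-yl)methyl in place of thiophen-2-yl on an aromatic carbon. Within the data shown here, the one measured single change, nitro in place of methoxy on an aromatic carbon, gives a number 7 percentage points lower from compound 1 to compound 2 (within the scatter), but it concerns a different group. No measurement tests the place that changes here, so no step beyond the scatter is expected in this assay. The expected step is a number 2 percentage points higher from compound 1 to compound 4 (within the scatter). For compound 4 the estimate is 42%, with an expected range from 25% to 60%.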

Compound 4, percent growth inhibition at one concentration: 29%
The estimate for compound 4 lay 13 percentage points above the measured number; measured number inside the range.
By their numbers in this assay, from the lowest: compounds 3, 4, 2 and 1 (each within the scatter of the next, the first and the last beyond it).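

Among these compounds, the swap to (naphthalen-1-yl)methyl gives a number 11 percentage points lower from compound 1 to compound 4 (beyond the scatter) in this assay at a place no earlier pair tested. This shows that the group on this aromatic carbon can shift the number beyond the scatter, though modestly, while the earlier single change, at a different group, stayed within it. No measurement here offers an explanation for this step.

From the compounds shown here alone, whether the step follows the two six-membered aromatic rings or the methyl link remains open. So does how an amine or a carboxylic acid would read at this place.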